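The source may report more compounds than this note shows. Statements on the series, on what has been measured and on what is new or still open speak of the compounds shown alone.

Four compounds share one core and differ only in the aryl group on a saturated chain carbon bound to an aromatic carbon and an oxygen on a saturated carbon: compound 1 (`Cc1oc2c([C@H]3CCN(C)C[C@H]3O)c(O)cc(O)c2c(=O)c1C(O)c1ccc(F)c(Br)c1`), compound 2 (`Cc1oc2c([C@H]3CCN(C)C[C@H]3O)c(O)cc(O)c2c(=O)c1C(O)c1c(Cl)cccc1Cl`), compound 3 (`Cc1oc2c([C@H]3CCN(C)C[C@H]3O)c(O)cc(O)c2c(=O)c1C(O)c1cc(F)cc(F)c1`) and the still unmeasured compound 4 (`Cc1oc2c([C@H]3CCN(C)C[C@H]3O)c(O)cc(O)c2c(=O)c1C(O)c1ccc(F)cc1`). In a functional assay on MCF7 cells (Homo sapiens) for inhibition, read by MTT assay, with a stated time of 48 h, tested at 10 uM (on this read-out lower numbers stand for less inhibition of growth and higher numbers for more inhibition of growth at the one concentration tested), compound 1 gives 14%, compound 2 gives 33% and compound 3 gives 25%. Compound 3 therefore cannot be told apart from compound 2, but it stands clear of compound 1.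

The next change puts 4-fluorophenyl in place of 3,5-difluorophenyl on a saturated chain carbon bound to an aromatic carbon and an oxygen on a saturated carbon. Three measured steps exchange the group at this same place. The step of a number 19 percentage points higher from compound 1 to compound 2 (beyond the scatter) and the step of a number 11 percentage points higher from compound 1 to compound 3 (beyond the scatter) were modest, while the step of a number 8 percentage points lower from compound 2 to compound 3 (within the scatter) stayed within the scatter. Even these exchanges of one whole aryl group for another moved this assay only modestly, so no step beyond the scatter is expected here. The 3-bromo-4-fluorophenyl group of compound 1, at 14%, tilts the expectation slightly downward. The expected step, a number 3 percentage points lower from compound 3 to compound 4 (within the scatter), lies within the scatter. For compound 4, the estimated value is 22%, with an expected range of 9% to 36%.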

Compound 4, percent growth inhibition at one concentration: 9%
Compound 4: middle estimate off by 13 percentage points, on the high side; measured number inside the range.
By their numbers in this assay, from the lowest: compounds 4 and 1 (each within the scatter of the next); then compounds 3 and 2 (each within the scatter of the next).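

In this assay, 4-fluorophenyl in place of 3,5-difluorophenyl gives a number 16 percentage points lower from compound 3 to compound 4 (beyond the scatter), and in place of 2,6-dichlorophenyl it gives a number 24 percentage points lower from compound 2 to compound 4 (beyond the scatter), so this place does respond to a change as small as going from one fluorophenyl group to another. Hydrogen in place of bromo on an aromatic carbon gives only a number 5 percentage points lower from compound 1 to compound 4 (within the scatter), so the bromo group of compound 1 makes no difference that can be read here. The four compounds now fall into two pairs: compound 1 and compound 4, whose aryl groups both carry 4-fluoro in their names, sit clearly under compound 3 and compound 2.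

Nothing at hand explains this split. From the compounds shown here alone, whether the low pair reflects a wider rule stays open, and a phenyl ring carrying an amine or a carboxylic acid at this place would test it.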